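Swapping the benzyl substituent in a sulfonyl guanidine series

The compounds below may be only part of what the source reports. "The series", "measured", "known", "first", "only" and "open" are said of these compounds alone.

Compound 1, `Cc1ccc(CSc2cc(Cl)c(C)cc2S(=O)(=O)/N=C(\N)n2nc(C)cc2-c2ccccc2)cc1`, gives 62000 nM in a functional assay on HeLa cells (Homo sapiens) for cytotoxicity, read by MTT assay, with a stated time of 72 h; a lower number here means a stronger inhibitor, a higher number a weaker inhibitor.
Compound 2, `Cc1cc(S(=O)(=O)/N=C(\N)n2nccc2-c2ccccc2)c(SCc2cccc(Cl)c2)cc1Cl`, gives 10000 nM in this assay.
Compound 3, `Cc1cccc(CSc2cc(Cl)c(C)cc2S(=O)(=O)/N=C(\N)n2nc(C)cc2-c2ccccc2)c1`, gives 155000 nM in this assay.

Among these three numbers compound 2 stands lowest, so it is the strongest inhibitor shown; compound 1 lies closest to it and compound 3 furthest away, both beyond the scatter. Compound 4, `Cc1cc(S(=O)(=O)/N=C(\N)n2nccc2-c2ccccc2)c(SCc2ccc(C(F)(F)F)cc2)cc1Cl`, is not yet measured. It differs from compound 2 in one place: 4-(trifluoromethyl)phenyl in place of 3-chlorophenyl on a saturated chain carbon bound to a sulfur.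

Going by the values given here, only one measured step exists, a 2.5-fold higher number from compound 1 to compound 3 (0.40 log units; beyond the scatter), and it concerns a different change on a core that also carries an extra methyl, so it bears on compound 4 only loosely. It does suggest that exchanging one benzyl substituent pattern for another moves this assay by a modest amount at most. Among the compounds with values here, no step with a trifluoromethyl group is available. A small step is therefore expected, with no confident direction: a 1.2-fold higher number from compound 2 to compound 4 (0.08 log units; within the scatter). Compound 4 is estimated at 12000 nM, within a range from 4000 nM to 40000 nM.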

Compound 4, half-maximal inhibitory concentration: 17000 nM
Compound 4: middle estimate off by 1.4-fold (0.15 log units), on the low side; the measured number falls inside the stated range.
By their numbers in this assay, from the lowest: compounds 2 and 4 (each within the scatter of the next); then compound 1; then compound 3.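

On the core of compound 2, the group on the saturated chain carbon bound to a sulfur can change from 3-chlorophenyl to 4-(trifluoromethyl)phenyl, with 10 heavy atoms in place of 7, and this assay still gives a 1.7-fold higher number from compound 2 to compound 4 (0.23 log units; within the scatter) between them. The two compounds therefore cannot be told apart here, so this position accepts both substituted rings with no measurable difference. That contrasts with a 2.5-fold higher number from compound 1 to compound 3 (0.40 log units; beyond the scatter) on the other core, although that step concerns a different change. No measurement on these groups accompanies the result, so the data offer no explanation for it.

As far as these compounds go, whether an amine or a carboxylic acid on this ring would shift the number beyond the scatter remains open. So does the effect of replacing the ring with a longer carbon chain.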